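Enlarging a methyl to a tert-butylphenyl on the shared core

A few compounds are considered here, and "the series" means these few. Any claim that something is new, unique, unknown or untested is made for them only; others in the source may bear on it.

Measured compounds:
Compound 1, `CC(C)(C)c1ccc(Cn2cc(-c3cn([C@H]4C[C@H](O)[C@@H](CO)O4)c(=O)[nH]c3=O)nn2)cc1`: 94.8%
Compound 2, `CC(=O)OC[C@H]1O[C@@H](n2cc(-c3cc(C)no3)c(=O)[nH]c2=O)C[C@@H]1OC(C)=O`: 90.8%

Of the compounds shown here, two have been tested in a functional assay on NUGC-3 cells (Homo sapiens) for cytotoxicity, read by sulforhodamine B assay, tested at 10 uM; on this read-out lower numbers stand for less inhibition and higher numbers for more inhibition at the one concentration tested (going by the name of the read-out). Compound 1 gives 94.8% in this assay. Compound 2 gives 90.8% in this assay, a number that lies within the usual scatter of the value of compound 1, so the two cannot be told apart on these data.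

Compound 3, `CC(=O)OC[C@H]1O[C@@H](n2cc(-c3cc(-c4ccc(C(C)(C)C)cc4)no3)c(=O)[nH]c2=O)C[C@@H]1OC(C)=O`, has not yet been measured. It differs from compound 2 in one place: 4-(tert-butyl)phenyl in place of methyl on an aromatic carbon. Among the compounds with values here, both measured compounds already show strong inhibition at the single concentration tested, and no measured pair shows what this kind of change does, so the expected step from compound 2 to compound 3 in this assay is none beyond the scatter, a number 0.8 percentage points lower from compound 2 to compound 3 (within the scatter). Compound 3 is therefore expected to give about 90% in this assay, with a range from 70% to 98%.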

Compound 3, a percentage reported as inhibition, at one concentration (the size of the read-out at that concentration, not a potency): 32.8%
The estimate for compound 3 lay 57.2 percentage points above the measured number, outside the stated range (below it).
By their numbers in this assay, from the lowest: compound 3; then compounds 2 and 1 (each within the scatter of the next).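

In this assay, the methyl on the five-membered aromatic ring with 1 nitrogen and 1 oxygen proves not to be freely exchangeable: 4-(tert-butyl)phenyl in its place gives a number 58 percentage points lower from compound 2 to compound 3 (beyond the scatter). Within the data shown here, this single position, on an aromatic carbon next to the ring nitrogen, can therefore change the read-out strongly on its own, something the earlier compounds could not show, as they offered no pair differing in one place. Nothing available here explains the drop.

Among these compounds, with only this one step, it stays open whether the loss goes with the added phenyl ring or with the tert-butyl at its end, and how a plain phenyl, an ethyl chain or an amine at this place would read. From the compounds shown here alone, each number also comes from a single concentration, so any shift in potency remains unknown.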